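Sulfonamide chain variation in a prostaglandin D2 receptor 2 series

The source may report more compounds than this note shows. Statements on the series, on what has been measured and on what is new or still open speak of the compounds shown alone.

Measured compounds:
- compound 1 `COCCN(C)S(=O)(=O)c1ccc(C)c(C#Cc2cc(Cl)ccc2OCC(=O)O)c1`: 4.1 nM
- compound 2 `CC(C)Cc1ccncc1C#Cc1cc(Cl)ccc1OCC(=O)O`: 4.9 nM
- compound 3 `Cn1ccnc1C#Cc1cc(Cl)ccc1OCC(=O)O`: 1470 nM

The read-out throughout is an assay on CHO cells for displacement of a labelled ligand from prostaglandin D2 receptor 2 (Homo sapiens), read by scintillation counting; on this read-out higher numbers stand for weaker inhibition and lower numbers for stronger inhibition. Compound 1 gives the lowest of the three numbers; compound 2 sits within the scatter of it, so no order between those two can be read, while compound 3 lies far beyond the scatter above both.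

The next compound in the series is compound 4 `Cc1ccc(S(=O)(=O)N(C)CCCN(C)C)cc1C#Cc1cc(Cl)ccc1OCC(=O)O`. It differs from compound 1 in one place: (dimethylamino)methyl in place of methoxy on a saturated chain carbon, two bonds along the chain from a sulfonamide nitrogen. Going by the values given here, no measured pair on the same change exists, so the step can only be expected. The change sits on the chain beyond the sulfonamide nitrogen, away from the shared core, and the expected step of a 1.2-fold higher number from compound 1 to compound 4 (0.09 log units; within the scatter) is none beyond the scatter. Compound 4 is therefore estimated at 5 nM, with a range from 1.5 nM to 20 nM in this assay.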

Compound 4, inhibition constant: 287 nM
Compound 4: middle estimate off by 57-fold (1.76 log units), on the low side; the measured number lies above the stated range.
By their numbers in this assay, from the lowest: compounds 1 and 2 (each within the scatter of the next); then compound 4; then compound 3.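

In this assay, going by these compounds alone, the chain beyond the sulfonamide nitrogen is not free to vary: (dimethylamino)methyl in place of methoxy gives a 70-fold higher number from compound 1 to compound 4 (1.85 log units; beyond the scatter), so this position tolerates far less than the earlier compounds could show. This single step covers one change on one core and gives no general rule for the chain. Nothing available explains the loss.

Open, going by these compounds, is whether the dimethylamino group or the longer chain carries the step. A 3-methoxypropyl chain or a 2-(dimethylamino)ethyl chain on the same core would separate the two.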